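This account rests on a few compounds, and the source may have more. Where it says the series, first, only, none or still open, it means among the compounds named here.

Compound 1 `Nc1ccc(Nc2c(C(=O)NCc3ccc(F)cc3)nc(Br)c3cccnc23)cc1` gives 7000 nM in a functional assay on HCT-116 cells (Homo sapiens) for cytotoxicity, read by MTT assay, with a stated time of 72 h; on this read-out lower numbers stand for stronger inhibition and higher numbers for weaker inhibition. Compound 2 `CS(=O)(=O)NCCCN(c1nc(C(=O)NCc2ccc(F)cc2)c(O)c2ncccc12)S(C)(=O)=O` gives 7000 nM in this assay, and the two values sit within the scatter of each other, so no order between compound 1 and compound 2 can be read from these numbers. For compound 3 `O=C(NCc1ccc(F)cc1)c1nc(NCCO)c2cccnc2c1O` the entry in this assay reads "not determined" (no result reported), so no number stands for it. Compound 4 `N[C@H]1CC[C@H](Nc2c(C(=O)NCc3ccc(F)cc3)nc(Br)c3cccnc23)CC1` differs from compound 1 by 4-aminocyclohexyl in place of 4-aminophenyl on a nitrogen on an aromatic ring. Within the data shown here, no measured pair in the set shows this change, so nothing here speaks for a shift in either direction; the expected step of no change at the digits printed from compound 1 to compound 4 (within the scatter) is therefore placed at about none beyond the scatter, with the range kept wide to cover that uncertainty. In this assay compound 4 is estimated at 7000 nM, expected between 2500 nM and 20000 nM.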

Compound 4, half-maximal inhibitory concentration: 4000 nM
Compound 4: the middle estimate sits 1.8-fold (0.24 log units) above what was measured, within the range that was stated.
By their numbers in this assay, from the lowest: compounds 4, 1 and 2 (each within the scatter of the next).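

Among these compounds, this is the first single-place change: a 1.8-fold lower number from compound 1 to compound 4 (0.24 log units; within the scatter) in this assay. At this place, on a nitrogen on an aromatic ring, 4-aminocyclohexyl and 4-aminophenyl cannot be told apart, so a non-aromatic carbon ring can stand in place of the aromatic one without a step beyond the scatter. No available data bear on why the two groups read alike.

Going by these compounds, it remains open whether an open-chain group such as 4-aminobutyl would also stay within the scatter. On these data alone, the effect of the other stereoisomer of 4-aminocyclohexyl is also open.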